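The compounds below may be only part of what the source reports. "The series", "measured", "known", "first", "only" and "open" are said of these compounds alone.

Among the compounds with values here, compound 2 `COc1cc(-c2cc(C(=O)O)c3ccccc3n2)ccc1OCC(=O)Nc1cccc(C)c1` gives 1.5 in a physicochemical assay for lipophilicity, using the shake flask method, in phosphate buffer, measured as octanol-water partition, at pH 7.4 (on this read-out lower numbers stand for lower lipophilicity and higher numbers for higher lipophilicity), and stands highest of the three numbers measured so far. Compound 3 `COc1cc(-c2cc(C(=O)O)c3ccccc3n2)ccc1OCC(=O)Nc1cccc(C(F)(F)F)c1` gives 1.3 in this assay, and compound 1 `COc1cc(-c2cc(C(=O)O)c3ccccc3n2)ccc1OCC(=O)Nc1ccccc1C` gives 0.8. The measured steps run as follows: a number 0.70 log units higher from compound 1 to compound 2 (beyond the scatter); a number 0.50 log units higher from compound 1 to compound 3 (beyond the scatter); a number 0.20 log units lower from compound 2 to compound 3 (within the scatter). Only the two steps that leave compound 1 are beyond the scatter, and compound 2 and compound 3 cannot be ordered against each other.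

The next compound, compound 4 `COc1cc(-c2cc(C(=O)O)c3ccccc3n2)ccc1OCC(=O)NCc1cccs1`, has not yet been measured in this assay. Its change from compound 2 is: (thiophen-2-yl)methyl in place of 3-methylphenyl on an amide-type nitrogen.

None of the three measured steps covers this change. Each of them exchanges one substituted phenyl for another on the amide-type nitrogen, whereas here the six-membered aromatic ring of carbon only leaves and a (thiophen-2-yl)methyl with one five-membered aromatic ring with one hetero atom and one hydrogen-bond acceptor enters. The measured series thus gives no direct anchor for the size of this step, and the expectation rests on the counted difference alone. A downward step of modest size beyond the scatter is expected, namely a number 0.60 log units lower from compound 2 to compound 4 (beyond the scatter). Compound 4 is accordingly expected to give 0.9 in this assay, with a range from 0.4 to 1.4.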

Compound 4, distribution coefficient: 0
For compound 4 the middle estimate is 0.90 log units above the measured one; measured number outside the range, below it.
By their numbers in this assay, from the lowest: compound 4; then compound 1; then compounds 3 and 2 (each within the scatter of the next).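

In this assay, within the data shown here, the amide-type nitrogen turns out to allow far larger steps than the exchanges among substituted phenyls showed: the change to (thiophen-2-yl)methyl gives a number 1.50 log units lower from compound 2 to compound 4 (beyond the scatter) and a number 1.30 log units lower from compound 3 to compound 4 (beyond the scatter) as large steps, where the earlier steps at this position stayed modest. The same change made on the 2-methylphenyl compound is smaller, with a number 0.80 log units lower from compound 1 to compound 4 (beyond the scatter) and of modest size, yet it points the same way, so compound 4 lies under all three phenyl amides whichever substituent is replaced. Nothing on hand gives a reason for this drop.

The (thiophen-2-yl)methyl differs from the phenyls both in its ring and in the chain that links the ring to the nitrogen, so the share of each in the step stays unresolved. A benzyl on the amide-type nitrogen, or a thiophen-2-yl joined to that nitrogen directly, would separate the two contributions, and a longer chain carrying the same ring would show whether the number keeps moving with chain length.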